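Trimming the second hydroxy of compound 1

This account rests on a few compounds, and the source may have more. Where it says the series, first, only, none or still open, it means among the compounds named here.

Compound 1 `O=C(C1=C(O)/C(=C/c2ccc(O)c(O)c2)CCC1)c1ccccc1` is one of three analogues measured in an assay on isolated protein for inhibition of Alpha glucosidase (Homo sapiens), with stated times of 5 min and 15 min, tested at 50 uM; on this read-out higher numbers stand for more inhibition at the one concentration tested (going by the name of the read-out) and lower numbers for less inhibition. Compound 1 gives 55.9%, the second highest of the three. Compound 2 `O=C1/C(=C/c2ccccc2)CCC/C1=C\c1ccc(O)cc1` gives 53%, within the scatter of compound 1, while compound 3 `O=C1/C(=C/c2ccccc2)CCC/C1=C\c1ccc(O)c(O)c1` gives 90.7%, well beyond it. For the measured compounds named here, the only single-point step measured, a number 37.7 percentage points higher from compound 2 to compound 3 (beyond the scatter), is a hydroxy in place of hydrogen. Compound 4 `O=C(C1=C(O)/C(=C/c2cccc(O)c2)CCC1)c1ccccc1` differs from compound 1 by hydrogen in place of hydroxy on an aromatic carbon, which runs the measured step in the opposite direction, so a drop in this assay for compound 4 seems the likelier outcome, though compound 2 shows a single hydroxy can still sit near compound 1. Compound 4 is therefore expected at 35%, between 15% and 58%, an estimated step of a number 20.9 percentage points lower from compound 1 to compound 4 (beyond the scatter).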

Compound 4, a percentage reported as inhibition, at one concentration (the size of the read-out at that concentration, not a potency): 43.2%
Estimate against measurement, compound 4: 8.2 percentage points below; the measured number falls inside the stated range.
By their numbers in this assay, from the lowest: compounds 4, 2 and 1 (each within the scatter of the next, the first and the last beyond it); then compound 3.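

Going from 3,4-dihydroxyphenyl to 3-hydroxyphenyl on the core of compound 1 gives a number 12.7 percentage points lower from compound 1 to compound 4 (beyond the scatter) in this assay, so this hydroxy also counts on a second core. The direction of the change holds across both cores, but its size does not carry over: the same change on two cores in this assay, a number 37.7 percentage points higher (beyond the scatter) from compound 2 to compound 3 and a number 12.7 percentage points higher (beyond the scatter) from compound 4 to compound 1, 25 percentage points apart, beyond the scatter of two such steps

Still open, from the compounds shown here alone, is whether another group at this position, such as an amine or a methoxy, could stand in for the hydroxy. The compounds shown also leave open what the hydroxy that remains in compound 4 contributes on this core.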